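Two Inactive Amides and a Third Built From Both

The compounds below may be only part of what the source reports. "The series", "measured", "known", "first", "only" and "open" are said of these compounds alone.

Compound 2 `C=CC1=C(C(=O)NCCCCC)C(c2ccc(OC)cc2)OC1` was tested in a functional assay on SW480 cells (Homo sapiens) for cytotoxicity, read by MTT assay, with a stated time of 24 h; on this read-out higher numbers stand for weaker inhibition and lower numbers for stronger inhibition. Compound 2 gives > 100000 nM, which is a limit of the assay rather than a number. Compound 1 `C=CC1=C(C(=O)NCc2ccc(C)cc2)C(c2ccc(F)cc2)OC1` fares the same way: compound 1 gives > 100000 nM, again a limit. Both sit at the limit of > 100000 nM in this assay, at which 2 of the 2 values shown sit, so compound 2 stands on no measurable number at all. Compound 3 `C=CC1=C(C(=O)NCc2ccc(C)cc2)C(c2ccc(OC)cc2)OC1` differs from compound 2 by 4-methylphenyl in place of butyl on a saturated chain carbon bound to an amide-type nitrogen. Within the data shown here, no measured step covers this change, and the step is expected to be a step that the limit leaves unreadable from compound 2 to compound 3, none beyond the scatter. Compound 3 is therefore expected at 150000 nM, between 60000 nM and 400000 nM, most likely again only a limit.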

Compound 3, half-maximal inhibitory concentration: 31700 nM
Compound 3: the middle estimate sits 4.7-fold (0.68 log units) above what was measured; measured number outside the range, below it.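

Replacing the pentyl chain of compound 2 with 4-methylbenzyl gives an at least 3.1-fold lower number from compound 2 to compound 3 (0.49 log units; beyond the scatter), so this side of the amide can change the result. Methoxy in place of fluoro on an aromatic carbon gives an at least 3.1-fold lower number from compound 1 to compound 3 (0.49 log units; beyond the scatter), so that site matters as well. From the compounds shown here alone, only compound 3, which carries both groups, gives a real number in this assay, and each step's full size remains unknown because its starting compound sits at a limit: the limit of > 100000 nM in this assay, at which 2 of the 3 values shown sit.

Going by these compounds, whether a hydroxy group in place of methoxy would preserve this activity remains open. So does the effect of a 4-chlorophenyl group in place of 4-methylphenyl.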